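The compounds below may be only part of what the source reports. "The series", "measured", "known", "first", "only" and "open" are said of these compounds alone.

In a functional assay on J774.A1 cells (Mus musculus) for inhibition, read by Griess assay, with stated times of 1 h and 24 h (on this read-out higher numbers stand for weaker inhibition and lower numbers for stronger inhibition), three compounds sharing one core have been measured. Compound 1 `O=C1CC(c2ccccc2OCc2ccc(F)cc2)Oc2ccccc21` gives 25500 nM and compound 2 `CC(C)c1ccc(COc2ccccc2C2CC(=O)c3ccccc3O2)cc1` gives 28600 nM on this measure, while compound 3 `CC(C)COc1ccccc1C1CC(=O)c2ccccc2O1` gives 33200 nM on the same measure. Compound 3 thus stands level with the other two, all three numbers lying within the scatter of one another.

The next compound, compound 4 `CCCCOc1ccccc1C1CC(=O)c2ccccc2O1`, has the same atoms as compound 3 joined differently, with propyl in place of isopropyl on a saturated chain carbon bound to an oxygen on an aromatic ring. Cut one bond further out, this reads isobutyl to butyl. For the measured compounds named here, no measured step makes this change itself. Going by the values given here, two steps touch the same chain carbon, and both (a 1.3-fold higher number from compound 1 to compound 3 (0.11 log units; within the scatter)) and (a 1.2-fold higher number from compound 2 to compound 3 (0.06 log units; within the scatter)) lie within the scatter, though they exchange 4-fluorophenyl and 4-isopropylphenyl for isopropyl. The step on an aromatic carbon (a 1.1-fold higher number from compound 1 to compound 2 (0.05 log units; within the scatter)) also lies within the scatter.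

Propyl in place of isopropyl is therefore expected to produce no step beyond the scatter in this assay and no favoured direction. The estimated step is small (a 1.1-fold lower number from compound 3 to compound 4 (0.04 log units; within the scatter)). Compound 4 is estimated at 30000 nM on this measure (expected range 18000 nM to 48000 nM).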

Compound 4, half-maximal inhibitory concentration: 47700 nM
For compound 4 the middle estimate is 1.6-fold (0.20 log units) below the measured one; low and high end bracket the measured number.
By their numbers in this assay, from the lowest: compounds 1, 2, 3 and 4 (each within the scatter of the next).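

In this assay, the change from isopropyl to propyl on a saturated chain carbon bound to an oxygen on an aromatic ring can now be read directly, and this rearrangement of the same atoms is a step within the scatter (a 1.4-fold higher number from compound 3 to compound 4 (0.16 log units; within the scatter)). Propyl also stays within the scatter of both compounds with an aromatic group at this place (a 1.7-fold higher number from compound 2 to compound 4 (0.22 log units; within the scatter); a 1.9-fold higher number from compound 1 to compound 4 (0.27 log units; within the scatter)), so all the steps printed here among 4-fluorophenyl, 4-isopropylphenyl, isopropyl and propyl at this position lie within the scatter, even though these groups differ in whether they hold a ring. Nothing is available that would explain this result or give it further support.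

The compounds shown leave open whether a group of another kind at this place, such as an amine, a carboxylic acid or a longer chain such as octyl, would give a step beyond the scatter. They also leave open whether a change elsewhere on the shared core, such as a hydroxyl on the ring that carries this chain, would do so.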